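Swapping a Dimethoxyphenyl for a Furan Ring

This account rests on a few compounds, and the source may have more. Where it says the series, first, only, none or still open, it means among the compounds named here.

Three measured compounds share one core, and a fourth compound is a close relative of one of them. Compound 1 `S=c1n(CN2CCCCC2)nc(Cc2ccccc2Nc2c(Cl)cccc2Cl)n1/N=C/c1ccccc1` was tested in an ADME assay on Vero cells (Chlorocebus sabaeus) for cytotoxicity, read by MTT assay, with a stated time of 72 h; a higher number here means that more compound is tolerated, a lower number that less compound is tolerated. In that assay compound 1 gives > 300000 nM, which is a limit of the assay rather than a number. Compound 2 `COc1ccc(/C=N/n2c(Cc3ccccc3Nc3c(Cl)cccc3Cl)nn(CN3CCCCC3)c2=S)cc1` gives "not determined" (no result reported) in this assay. Compound 3 `COc1ccc(/C=N/n2c(Cc3ccccc3Nc3c(Cl)cccc3Cl)nn(CN3CCCCC3)c2=S)cc1OC` likewise gives "not determined" (no result reported) in this assay, so compound 3 stands without a number of its own. Thus among the three entries, two have no number at all. Compound 4 `S=c1n(CN2CCCCC2)nc(Cc2ccccc2Nc2c(Cl)cccc2Cl)n1/N=C/c1ccco1` differs from compound 3 in a single place: furan-2-yl in place of 3,4-dimethoxyphenyl on a carbon with a double bond to nitrogen. Among the measured compounds shown here, no measured step between any two compounds is available to show how large an effect a change of this kind has in this assay, and the one value that exists is the limit of > 300000 nM in this assay, at which 1 of the 3 values shown sits. The expectation is therefore a step of no clear direction, not beyond the scatter. Compound 4 is expected to give 300000 nM in this assay, with a range from 100000 nM to 1000000 nM, most likely reported again only as a limit.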

Compound 4, half-maximal cytotoxic concentration: > 300000 nM
Compound 4 ended at the assay's limit (the forecaster's own chance of this, stated with the estimate: 70%); the middle value lies on the limit itself.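

Compound 1 and compound 4 both stop at a limit of the assay rather than a number, so no step between them can be read: the limit of > 300000 nM in this assay, at which 2 of the 4 values shown sit.

Still open, as far as these compounds go, is whether furan-2-yl in place of phenyl changes how much compound the cells tolerate.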